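Isobutoxy to 3,3,3-trifluoropropoxy on the shared core

This account rests on a few compounds, and the source may have more. Where it says the series, first, only, none or still open, it means among the compounds named here.

Going by the values given here, in a physicochemical assay for solubility (a lower number here means a less soluble compound, a higher number a more soluble compound), compound 1 `CC(C)Oc1ccc(S(C)(=O)=O)cc1C(=O)N1Cc2cc(C(F)(F)F)cnc2C1` gives 114 ug/mL and compound 2 `CC(C)COc1ccc(S(C)(=O)=O)cc1C(=O)N1Cc2cc(C(F)(F)F)cnc2C1` gives 445 ug/mL, the higher of the two numbers so far. Compound 3 `CS(=O)(=O)c1ccc(OCCC(F)(F)F)c(C(=O)N2Cc3cc(C(F)(F)F)cnc3C2)c1` keeps the shared core and carries 2,2,2-trifluoroethyl in place of isopropyl on a saturated chain carbon bound to an oxygen on an aromatic ring. Among the compounds with values here, one measured step bears on this change, a 3.9-fold higher number from compound 1 to compound 2 (0.59 log units; beyond the scatter), a modest step at the same chain. Within the data shown here, that step swaps one plain alkyl group for another, and no measured compound carries fluorine on this chain, so it offers a guide to size but little guide to direction. Among the measured compounds shown here, with compound 2 at the top of only two numbers, a modest fall is expected. The expected step is a 2.2-fold lower number from compound 2 to compound 3 (0.35 log units; beyond the scatter). For compound 3 the estimate is 200 ug/mL, with an expected range of 60 ug/mL to 650 ug/mL.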

Compound 3, solubility: 513 ug/mL
Estimate against measurement, compound 3: 2.6-fold (0.41 log units) below, and the stated range covers the measured number.
By their numbers in this assay, from the lowest: compound 1; then compounds 2 and 3 (each within the scatter of the next).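

In this assay the swap of isobutoxy for 3,3,3-trifluoropropoxy on the shared core gives a 1.2-fold higher number from compound 2 to compound 3 (0.06 log units; within the scatter) and so separates the two chains by no more than the scatter. Set against isopropyl on an oxygen on an aromatic ring, 3,3,3-trifluoropropyl gives a 4.5-fold higher number from compound 1 to compound 3 (0.65 log units; beyond the scatter) and isobutyl gives a 3.9-fold higher number from compound 1 to compound 2 (0.59 log units; beyond the scatter) as a step of similar size, so both groups stand apart from isopropyl at this position. No supporting measurement bears on why these numbers fall as they do.

Open, from the compounds shown here alone, is where a straight propyl chain, a longer chain such as pentyl or a terminal amine on this oxygen would fall against these numbers. Also open, going by these compounds, is whether isobutoxy and 3,3,3-trifluoropropoxy stay level on any other core.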